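A few compounds are considered here, and "the series" means these few. Any claim that something is new, unique, unknown or untested is made for them only; others in the source may bear on it.

Working notes on the series. Compound 1 `C#CCNC1CCc2c(OCCCCN3CCN(c4cccc5c4ccn5Cc4cccc(Cl)c4)CC3)cccc21` has been run in an assay on BTI cells for inhibition of Amine oxidase [flavin-containing] B (Homo sapiens), read by fluorescence, with stated times of 30 min and 1 h, tested at 1 uM (a lower number here means less inhibition, a higher number more inhibition at the concentration tested (going by the name of the read-out)), where compound 1 gives 100%. For the measured compounds named here, of the two numbers in hand, compound 1 stands highest; the only other measured member, compound 2 `C#CCNC1CCc2c(OCCCCCN3CCN(c4cccc5c4ccn5Cc4cccc(Cl)c4)CC3)cccc21`, gives 80% in this assay, a gap that lies beyond the usual scatter. Going by the values given here, no single-point step between measured compounds has been recorded, so nothing yet isolates the effect of any one change.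

Compound 3 `C#CCNC1CCc2c(OCCCCN3CCN(c4cccc5c4ccn5S(=O)(=O)c4ccccc4)CC3)cccc21` remains to be measured. Relative to compound 1 it carries phenylsulfonyl in place of 3-chlorobenzyl on an aromatic nitrogen. Among the compounds with values here, no measured pair speaks to this change, so the expectation rests on compound 1 alone, which already gives the maximum the read-out can report in this assay; compound 3 can at best match it. The expected step in this assay is a number 15 percentage points lower from compound 1 to compound 3 (beyond the scatter), a modest loss. For compound 3 the estimate in this assay is 85%, with a range from 55% to 100%.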

Compound 3, a percentage reported as inhibition, at one concentration (the size of the read-out at that concentration, not a potency): 44%
Beside the measured number, compound 3's estimate is 41 percentage points above it, outside the stated range (below it).
By their numbers in this assay, from the lowest: compound 3; then compound 2; then compound 1.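

Phenylsulfonyl in place of 3-chlorobenzyl on the aromatic nitrogen gives in this assay a number 56 percentage points lower from compound 1 to compound 3 (beyond the scatter) and is the only single-place step in the series so far, showing that the read-out responds strongly to the group at this position. Inhibition is reduced but not lost, as compound 3 still gives 44% at the concentration tested, so this position accepts a sulfonyl-linked phenyl ring with a clear cost. Nothing at hand bears on why the step has this size.

The change replaces the methylene link with a sulfonyl and also removes the chlorine, so the compounds shown cannot apportion the loss between the two. An unsubstituted benzyl group and a 3-chlorophenylsulfonyl group on the same nitrogen would separate these contributions.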